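A few compounds are considered here, and "the series" means these few. Any claim that something is new, unique, unknown or untested is made for them only; others in the source may bear on it.

Measured in a functional assay on SGC-7901 cells (Homo sapiens) for antiproliferative activity, read by MTT assay, with a stated time of 24 h; a lower number here means a stronger inhibitor, a higher number a weaker inhibitor:
- compound 1 `Cc1ccccc1NNC(=O)c1ccc(NS(=O)(=O)c2cnc(O)nc2O)cc1`: > 20000 nM
- compound 2 `Cc1ccccc1NNC(=O)c1ccccc1NS(=O)(=O)c1cnc(O)nc1O`: > 20000 nM

Both entries are limits of the assay and not numbers. Compound 2 gives > 20000 nM, which is a limit, so its position in the series can be stated only as a bound. Within the data shown here, the same holds for compound 1, and the record for this assay so far reads: the limit of > 20000 nM in this assay, at which 2 of the 2 values shown sit.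

Compound 3 `Cc1cccc(NNC(=O)c2ccccc2NS(=O)(=O)c2cnc(O)nc2O)c1` is the next compound in line and has the same atoms as compound 2, joined differently. It carries 3-methylphenyl in place of 2-methylphenyl on an amine nitrogen. Among the measured compounds shown here, no step between measured compounds is available, so the size of this change can only be expected.

The expected result in this assay is a number no higher from compound 2 to compound 3 (the limit leaves the size open), which means no change beyond the scatter, and a further limit is the likeliest report. This expectation rests on compound 2, whose > 20000 nM is a limit. For compound 3 the estimate is 20000 nM, with an expected range of 7000 nM to 40000 nM.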

Compound 3, half-maximal inhibitory concentration: > 20000 nM
Compound 3 was reported as a limit (the forecaster's own chance of this, stated with the estimate: 70%); the middle value lies on the limit itself.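

In this assay compound 3 gives > 20000 nM, which is a limit and not a number. With compound 2 also reported as a limit, no step between compound 2 and compound 3 can be read: the limit of > 20000 nM in this assay, at which 3 of the 3 values shown sit.

The compounds shown leave open whether 3-methylphenyl in place of 2-methylphenyl makes any difference, and where any of the three compounds would fall as a number.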